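The source may hold more compounds than are shown below. What is called first, only, known or untested is meant among the compounds shown, and "the series" means these compounds.

Working notes on the series. Three compounds built on the shared core of compound 2 `CC1CCN(c2nc(C(F)(F)Cl)ccc2CNC(=O)C(C)c2ccc(NS(C)(=O)=O)c(F)c2)CC1` have been read in an assay on CHO cells for antagonist activity at transient receptor potential cation channel subfamily V member 1 (Homo sapiens), read by FLIPR; a higher number here means a weaker inhibitor, a lower number a stronger inhibitor. Compound 1 `Cc1ccc(CNC(=O)C(C)c2ccc(NS(C)(=O)=O)c(F)c2)c(N2CCC(C)CC2)n1` gives 72.1 nM. Compound 2 gives 0.3 nM and stands lowest of the three numbers. Compound 3 `CC1CCN(c2nc(-c3ccc(F)cc3)ccc2CNC(=O)C(C)c2ccc(NS(C)(=O)=O)c(F)c2)CC1` gives 59 nM. All steps among them sit on one aromatic carbon of the core: a 240-fold lower number from compound 1 to compound 2 (2.38 log units; beyond the scatter), a 1.2-fold lower number from compound 1 to compound 3 (0.09 log units; within the scatter) and a 200-fold higher number from compound 2 to compound 3 (2.29 log units; beyond the scatter).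

Compound 4 `CC(C(=O)NCc1ccc(C(F)(F)Cl)nc1N1CCN(c2ccccc2)CC1)c1ccc(NS(C)(=O)=O)c(F)c1` is not yet measured. It keeps the chloro(difluoro)methyl group of compound 2 and differs elsewhere: 4-phenylpiperazin-1-yl in place of 4-methylpiperidin-1-yl on an aromatic carbon. For the measured compounds named here, none of the measured steps touches this place; all three vary the group on the other aromatic carbon, so they give no direct guide to an exchange of the group on the aromatic carbon next to the ring nitrogen. The large swings between compound 2 and compound 1 or compound 3 came from the group that compound 4 retains. The expectation is therefore a change no larger than the scatter, or at most a modest loss, with an estimated step of a 4.0-fold higher number from compound 2 to compound 4 (0.60 log units; beyond the scatter) in this assay. Compound 4 is estimated at 1.2 nM, with a range from 0.2 nM to 8 nM.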

Compound 4, inhibition constant: 0.8 nM
Compound 4: the middle estimate sits 1.5-fold (0.18 log units) above what was measured; measured number inside the range.
By their numbers in this assay, from the lowest: compound 2; then compound 4; then compounds 3 and 1 (each within the scatter of the next).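

For the compounds shown here, the aromatic carbon next to the ring nitrogen, which no earlier step touched, now has a first reading: in this assay, 4-phenylpiperazin-1-yl in place of 4-methylpiperidin-1-yl gives a 2.7-fold higher number from compound 2 to compound 4 (0.43 log units; beyond the scatter), a modest step, although the entering group brings 12 heavy atoms against 7 and an added six-membered aromatic ring of carbon only. With the chloro(difluoro)methyl group held, this exchange costs far less than a 200-fold higher number from compound 2 to compound 3 (2.29 log units; beyond the scatter), the step at the other aromatic carbon, and compound 4 stays at 0.8 nM, so this position takes a much larger group with only a modest shift in the number. Nothing measured here accounts for the size of this step.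

Going by these compounds alone, the single exchange does not separate the part played by the piperazine ring from that of its phenyl group, and a morpholin-4-yl or 4-benzylpiperidin-1-yl group at this position could help to tell them apart. Going by these compounds, whether the step keeps its size with methyl or 4-fluorophenyl on the other aromatic carbon also stays open.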